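Methyl on the amide nitrogen of compound 2

This account rests on a few compounds, and the source may have more. Where it says the series, first, only, none or still open, it means among the compounds named here.

In a functional assay on MCF7 cells (Homo sapiens) for antiproliferative activity, read by CCK-8 assay, with a stated time of 48 h (on this read-out lower numbers stand for stronger inhibition and higher numbers for weaker inhibition), compound 1 `C/C=C/C(=O)N1CC(Oc2ccc(Oc3c(-c4ccc(F)cc4)sc4cc(O)ccc34)cc2)C1` gives 28000 nM and compound 2 `CNC(=O)/C=C/CNCCOc1ccc(Oc2c(-c3ccc(F)cc3)sc3cc(O)ccc23)cc1` gives 16100 nM, so compound 2 stands level with compound 1 within the scatter. Compound 3 `CN(C)C(=O)/C=C/CNCCOc1ccc(Oc2c(-c3ccc(F)cc3)sc3cc(O)ccc23)cc1` carries methyl in place of hydrogen on an amide-type nitrogen, methyl in place of hydrogen on an amide-type nitrogen. Going by the values given here, no measured step isolates this change. The only one, a 1.7-fold lower number from compound 1 to compound 2 (0.24 log units; within the scatter), exchanges the whole group on the oxygen and stays within the scatter. No shift beyond the scatter is therefore expected in this assay, and the expected step is a 1.0-fold lower number from compound 2 to compound 3 (0.00 log units; within the scatter). Compound 3 is estimated at 16000 nM, with an expected range of 7000 nM to 35000 nM.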

Compound 3, half-maximal inhibitory concentration: 13800 nM
Estimate against measurement, compound 3: 1.2-fold (0.06 log units) above; the measured number falls inside the stated range.
By their numbers in this assay, from the lowest: compounds 3, 2 and 1 (each within the scatter of the next, the first and the last beyond it).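

In this assay, methyl in place of hydrogen on the amide-type nitrogen gives a 1.2-fold lower number from compound 2 to compound 3 (0.07 log units; within the scatter) and so leaves the number level with that of the parent amide. Going by these compounds alone, the exchange of the whole group on the oxygen now reads a 2.0-fold lower number from compound 1 to compound 3 (0.31 log units; beyond the scatter) and is the only step in the set beyond the scatter, though a modest one. No available evidence bears on the reason for either step.

Open, on these data alone, is whether a larger group on this nitrogen, such as ethyl or a pyrrolidine amide, keeps the number at this level. Also open, as far as these compounds go, is how a carboxylic acid in place of the dimethylcarbamoyl group would read.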